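The compounds below may be only part of what the source reports. "The series", "measured", "known", "first", "only" and "open" are said of these compounds alone.

Measured so far:
- compound 1 `CCCCCNC(=O)n1c(-c2ccccc2)coc1=O`: 25 nM in an assay on isolated protein for inhibition of acid ceramidase (Homo sapiens), read by LC-MS, with a stated time of 1 h; a lower number here means a stronger inhibitor, a higher number a weaker inhibitor
- compound 2 `O=C(NCCCCc1ccccc1)n1cc(-c2ccccc2)oc1=O`: 90 nM in this assay
- compound 3 `CC(C)CNC(=O)n1cc(-c2ccccc2)oc1=O`: 1700 nM in this assay

Among these three numbers, compound 2 stands second highest. Compound 1 shows a lower number than compound 2, and compound 3 a far higher one; both gaps lie beyond the usual scatter. Compound 4 `O=C(NCCCCc1ccccc1)n1cc(-c2ccncc2)oc1=O` has not yet been measured. It differs from compound 2 in one place: pyridin-4-yl in place of phenyl on an aromatic carbon. Within the data shown here, no measured pair shows this kind of change, so the size of the step is not known from the data. Only a small step is expected, toward a higher number or none beyond the scatter. Compound 4 is expected to give about 200 nM in this assay, within 60 nM to 800 nM, a step of a 2.2-fold higher number from compound 2 to compound 4 (0.35 log units; beyond the scatter).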

Compound 4, half-maximal inhibitory concentration in the acid ceramidase assay: 18 nM
Beside the measured number, compound 4's estimate is 11-fold (1.05 log units) above it; measured number outside the range, below it.
By their numbers in the acid ceramidase assay, from the lowest: compounds 4 and 1 (each within the scatter of the next); then compound 2; then compound 3.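

Placing pyridin-4-yl instead of phenyl on the aromatic carbon next to the ring oxygen gives, in the acid ceramidase assay, a 5.0-fold lower number from compound 2 to compound 4 (0.70 log units; beyond the scatter). Among these compounds, this is the first pair that differs at this place alone, and it shows that a ring nitrogen in this aromatic group is tolerated and goes with a lower number.

The same change cannot be read in a physicochemical assay for solubility, read by HPLC, in phosphate buffer, measured as kinetic solubility, with a stated time of 1 h, at pH 7.4, tested at 250 uM (a higher number here means a more soluble compound, a lower number a less soluble compound), where both compounds sit at an assay limit: the limit of < 1000 nM in the physicochemical assay, at which 2 of the 2 values shown sit. In the physicochemical assay compound 2 gives < 1000 nM as a limit of the assay and not a number. In the physicochemical assay compound 4 gives < 1000 nM as a limit of the assay and not a number. From the compounds shown here alone, whether pyridin-3-yl, or a phenyl ring carrying an amine or a carboxylic acid, would give a similar step remains open.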